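Dropping the chloro from compound 1: an expectation

The compounds below may be only part of what the source reports. "The series", "measured", "known", "first", "only" and "open" are said of these compounds alone.

Measured compounds and their values:
compound 1 `O=C(Nc1cc(C(F)(F)F)ccc1N1CCCC1)c1cccnc1Cl` — "not active" (no number reported)
compound 2 `O=C(Nc1cc(C(F)(F)F)ccc1N1CCCCC1)c1cccnc1Cl` — "not active" (no number reported)
compound 3 `O=C(Nc1cc(C(F)(F)F)ccc1Nc1ccc(Br)cc1)c1ccccc1` — 33800 nM

In a functional assay on Jurkat cells (Homo sapiens) for cytotoxicity, read by MTT assay, with a stated time of 48 h (on this read-out higher numbers stand for weaker inhibition and lower numbers for stronger inhibition), compound 1 is recorded without a single number, only as "not active" (no number reported). Compound 2 stands the same way in this assay, giving "not active" (no number reported). Among the compounds with values here, the one numbered value belongs to compound 3, which in this assay gives 33800 nM; no step between it and compound 1 is counted, so their values are only set side by side, and both sit at the weak end of the read-out.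

Compound 4 `O=C(Nc1cc(C(F)(F)F)ccc1N1CCCC1)c1cccnc1` has not yet been measured. It differs from compound 1 by one change: hydrogen in place of chloro on an aromatic carbon. Within the data shown here, no comparable pair among the measured compounds exists, so the size of this step in this assay cannot be read from them. Since compound 1 gives no number, the author expects compound 4 to stay weak as well, with a fair chance that the read-out again reports no number. Compound 4 is estimated at 40000 nM, with a range from 10000 nM to 150000 nM.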

Compound 4, half-maximal inhibitory concentration: "not active" (no number reported)
The entry for compound 4 holds no number; there is nothing to compare the estimate with.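

No step can be read between compound 1 and compound 4 in this assay and neither entry holds a number: compound 1 gives "not active" (no number reported) and compound 4 gives "not active" (no number reported) alike. The compounds shown leave open whether the change from 2-chloropyridin-3-yl to pyridin-3-yl has any size at all in this assay and no measurement here offers an explanation for the result.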